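Trading tert-butyl for chlorophenyl on the sulfur

The source may report more compounds than this note shows. Statements on the series, on what has been measured and on what is new or still open speak of the compounds shown alone.

Measured compounds in a functional assay for inhibition of sodium/hydrogen exchanger (Oryctolagus cuniculus); on this read-out higher numbers stand for weaker inhibition and lower numbers for stronger inhibition:
Compound 1 `Cc1cc(-c2ccco2)c(S(C)(=O)=O)cc1C(=O)N=C(N)N`: 16 nM
Compound 2 `CSc1cc(C)c(C(=O)N=C(N)N)cc1S(C)(=O)=O`: 6 nM
Compound 3 `Cc1cc(SC(C)(C)C)c(S(C)(=O)=O)cc1C(=O)N=C(N)N`: 22 nM

Compound 3 gives the highest of the three numbers; its gap to compound 1 is within the scatter, its gap to compound 2 beyond it. Compound 4 `Cc1cc(Sc2ccccc2Cl)c(S(C)(=O)=O)cc1C(=O)N=C(N)N` differs from compound 3 in one place: 2-chlorophenyl in place of tert-butyl on a sulfur.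

Going by the values given here, two measured steps touch the same position. Enlarging the group on the sulfur gave a 3.7-fold higher number from compound 2 to compound 3 (0.56 log units; beyond the scatter), a modest weakening. Exchanging a ring attached directly to the aromatic carbon for the (tert-butyl)sulfanyl group gave a 1.4-fold higher number from compound 1 to compound 3 (0.14 log units; within the scatter), nothing beyond the scatter. An aromatic ring on the sulfur is new to this series, so the step from compound 3 to compound 4 is uncertain; a small change either way is the expectation, and the estimate sets it at a 1.5-fold lower number from compound 3 to compound 4 (0.17 log units; within the scatter). Compound 4 is therefore expected to give about 15 nM, with a range from 5 nM to 50 nM.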

Compound 4, half-maximal inhibitory concentration: 14 nM
For compound 4 the middle estimate is 1.1-fold (0.03 log units) above the measured one, within the range that was stated.
By their numbers in this assay, from the lowest: compound 2; then compounds 4, 1 and 3 (each within the scatter of the next).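

In this assay, the sulfur carries an aromatic ring as readily as a branched group: 2-chlorophenyl in place of tert-butyl gives a 1.6-fold lower number from compound 3 to compound 4 (0.20 log units; within the scatter), so the two cannot be told apart. Methyl on the sulfur still keeps its edge over this ring, with a 2.3-fold higher number from compound 2 to compound 4 (0.37 log units; beyond the scatter), a modest weakening that matches the one seen with tert-butyl. Placing the ring on the sulfur also leaves the number level with that of furan-2-yl on the aromatic carbon, at a 1.1-fold lower number from compound 1 to compound 4 (0.06 log units; within the scatter).

No measurement shown here explains these numbers. Going by these compounds, it remains open whether the chlorine matters, which a plain phenyl on the sulfur would test, and how a group such as ethyl, a step up from methyl, would fall between these values.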